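Swapping a hydroxy for a fluoro on the side ring

The compounds below may be only part of what the source reports. "The series", "measured", "known", "first", "only" and "open" are said of these compounds alone.

Of the compounds shown here, three sharing one core have been tested in a functional assay, with a stated time of 10 min; a higher number here means a weaker inhibitor, a lower number a stronger inhibitor. Compound 1, `CCOC(=O)c1cnn(-c2nc(-c3ccccc3Cl)c(C#N)c(=O)n2C)c1N`, gives 98 ug/mL. Compound 2, `CCOC(=O)c1cnn(-c2nc(-c3ccc(Cl)cc3)c(C#N)c(=O)n2C)c1N`, in which 4-chlorophenyl replaces 2-chlorophenyl, gives 94 ug/mL; the step is a 1.0-fold lower number from compound 1 to compound 2 (0.02 log units; within the scatter). Compound 3, `CCOC(=O)c1cnn(-c2nc(-c3ccccc3O)c(C#N)c(=O)n2C)c1N`, carries a hydroxy in place of the chloro and gives 58 ug/mL. Among the measured compounds shown here, it has the lowest number of the three, but the steps to it, a 1.7-fold lower number from compound 1 to compound 3 (0.23 log units; within the scatter) and a 1.6-fold lower number from compound 2 to compound 3 (0.21 log units; within the scatter), both lie within the scatter, so no compound can be called stronger than another on these figures.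

Compound 4, `CCOC(=O)c1cnn(-c2nc(-c3ccccc3F)c(C#N)c(=O)n2C)c1N`, is the next step from compound 3. The change is fluoro in place of hydroxy on an aromatic carbon. For the measured compounds named here, the step that bears most directly on it is the one from compound 1 to compound 3, where a chloro gave way to a hydroxy at this same place and the number moved only within the scatter. Replacing the hydroxy with another halogen-type group is expected to move the number back toward that of compound 1, again by no more than the scatter allows.

Compound 4 is therefore estimated at 80 ug/mL, with a range from 45 ug/mL to 140 ug/mL, meaning an expected step of a 1.4-fold higher number from compound 3 to compound 4 (0.14 log units; within the scatter) in this assay.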

Compound 4, half-maximal inhibitory concentration: 86 ug/mL
Estimate against measurement, compound 4: 1.1-fold (0.03 log units) below; the measured number falls inside the stated range.
By their numbers in this assay, from the lowest: compounds 3, 4, 2 and 1 (each within the scatter of the next).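

In this assay, the hydroxy on this aromatic carbon, ortho to a large group, counts as one hydrogen-bond donor and one hydrogen-bond acceptor, while the fluoro that enters counts as neither, and the exchange gives a 1.5-fold higher number from compound 3 to compound 4 (0.17 log units; within the scatter); removing both counts therefore leaves no readable mark on the number. Fluoro also cannot be told apart from either chloro compound, with fluoro in place of chloro at this same place giving a 1.1-fold lower number from compound 1 to compound 4 (0.06 log units; within the scatter), and 2-fluorophenyl in place of 4-chlorophenyl giving a 1.1-fold lower number from compound 2 to compound 4 (0.04 log units; within the scatter). Nothing measured here offers an explanation for how these compounds relate to one another.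

Each of the compounds shown carries a single heavy atom as its substituent on the side ring, so it remains open whether a larger or differently built group at this place, such as a methoxy, an amine or a carboxylic acid, would give a step beyond the scatter. Among the compounds shown here, every step so far also lies on the side ring, which leaves open how the number responds to changes in the rest of the shared core.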